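A few compounds are considered here, and "the series" means these few. Any claim that something is new, unique, unknown or untested is made for them only; others in the source may bear on it.

Measured so far in a functional assay on HepG2 cells (Homo sapiens) for antiproliferative activity, read by MTT assay, with a stated time of 24 h; a higher number here means a weaker inhibitor, a lower number a stronger inhibitor:
Compound 1 `COc1ccc(C(=O)/C=C/c2ccc(-c3ccccc3)cc2)c2c1C=CC(C)(C)O2` gives > 10000 nM, which is a limit of the assay rather than a number.
Compound 2 `COc1ccc(C(=O)/C=C/c2cccc([N+](=O)[O-])c2)c2c1C=CC(C)(C)O2` gives 2830 nM.
Compound 3 `COc1ccc(C(=O)/C=C/c2cccc3ccccc23)c2c1C=CC(C)(C)O2` gives > 10000 nM, again a limit rather than a number.

For the measured compounds named here, compound 2 is thus the only compound with a numerical value in this assay; the other two sit at the limit of > 10000 nM in this assay, at which 2 of the 3 values shown sit. Compound 4 `COc1ccc(C(=O)/C=C/c2ccccc2Cl)c2c1C=CC(C)(C)O2` has not yet been measured. It differs from compound 2 in one place: 2-chlorophenyl in place of 3-nitrophenyl on a double-bonded chain carbon bound to a double-bonded chain carbon. Going by the values given here, no step between two measured compounds is available to guide the size of this change. In this assay the expected step is a 2.1-fold higher number from compound 2 to compound 4 (0.33 log units; beyond the scatter), a mild weakening that may reach the limit. Compound 4 is therefore estimated at 6000 nM, within 2000 nM to 20000 nM.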

Compound 4, half-maximal inhibitory concentration: > 10000 nM
Compound 4: a limit, no number; the forecaster's own chance of this, stated with the estimate: 40%; middle value at least 1.6-fold (0.22 log units) away from the limit.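

In this assay, for the compounds shown here, 2-chlorophenyl in place of 3-nitrophenyl gives an at least 3.5-fold higher number from compound 2 to compound 4 (0.54 log units; beyond the scatter), the first measured step at this position, and it points towards weaker activity. Compound 4 gives a limit of the assay rather than a number, so the full size of the step remains unknown and compound 2 is still the only compound with a number: the limit of > 10000 nM in this assay, at which 3 of the 4 values shown sit.

The compounds shown leave open whether the change follows from the nitro group leaving or the chlorine entering, as both happen in one step. An unsubstituted phenyl ring or an aminophenyl ring at this place could help separate the two.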